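The source may hold more compounds than are shown below. What is called first, only, known or untested is meant among the compounds shown, and "the series" means these compounds.

Measured so far:
compound 1, `O=C(/C=C/c1ccoc1)c1cc(O)c(O)c([N+](=O)[O-])c1`, 52900 nM
compound 2, `O=C(/C=C/c1ccco1)c1cc(O)c(O)c([N+](=O)[O-])c1`, 60500 nM

In an assay on isolated protein for inhibition of Amine oxidase [flavin-containing] A (Homo sapiens), read by fluorescence (on this read-out lower numbers stand for stronger inhibition and higher numbers for weaker inhibition), compound 1 gives 52900 nM and compound 2 gives 60500 nM. Compound 2 carries the higher of the two numbers, yet the step of a 1.1-fold higher number from compound 1 to compound 2 (0.06 log units; within the scatter) falls inside the usual scatter, so the two values show no real difference between them.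

Compound 3, `Cn1cc(/C=C/C(=O)c2cc(O)c(O)c([N+](=O)[O-])c2)cn1`, has not yet been measured in this assay. Its difference from compound 2 is 1-methyl-1H-pyrazol-4-yl in place of furan-2-yl on a double-bonded chain carbon bound to a double-bonded chain carbon. For the measured compounds named here, the only measured step that bears on such a change is the exchange of one five-membered aromatic ring for another, a 1.1-fold higher number from compound 1 to compound 2 (0.06 log units; within the scatter), which was within the scatter. On that basis the ring exchange is expected to move this assay little, if at all; the step from compound 2 to compound 3 is estimated as a 1.0-fold lower number from compound 2 to compound 3 (0.00 log units; within the scatter). Compound 3 is therefore expected near 60000 nM, with a range from 20000 nM to 180000 nM.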

Compound 3, half-maximal inhibitory concentration: 51500 nM
Estimate against measurement, compound 3: 1.2-fold (0.07 log units) above, and the stated range covers the measured number.
By their numbers in this assay, from the lowest: compounds 3, 1 and 2 (each within the scatter of the next).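

At this place, on a double-bonded chain carbon bound to a double-bonded chain carbon, 1-methyl-1H-pyrazol-4-yl stands in for furan-2-yl with a 1.2-fold lower number from compound 2 to compound 3 (0.07 log units; within the scatter) and for furan-3-yl with a 1.0-fold lower number from compound 1 to compound 3 (0.01 log units; within the scatter), both in this assay. For the compounds shown here, the earlier pair exchanged only one ring with 1 hetero atom for another, whereas a ring with 2 hetero atoms and a methyl group also leaves the read-out of this assay within the scatter, so these three five-membered aromatic rings cannot be told apart there. Nothing on hand explains why they read alike.

As far as these compounds go, it remains open whether any group at this place can move the number, as all three values lie within the scatter of one another. A phenyl ring, an amine or a carboxylic acid there would test this, and the shared core stays unvaried throughout.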